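A few compounds are considered here, and "the series" means these few. Any claim that something is new, unique, unknown or untested is made for them only; others in the source may bear on it.

Working notes on the sulfonyl benzylamide series in an ADME assay on microsomes from liver (Homo sapiens) for metabolic stability, read by LC-MS, with a stated time of 30 min, tested at 1 uM; on this read-out higher numbers stand for a more stable compound and lower numbers for a less stable compound.

Of the compounds shown here, three carry numbers so far. Compound 1 `Cn1c(C(=O)NCc2ccc(S(=O)(=O)c3ccccc3)cc2)cc2cnccc21` gives 78%. Compound 2 `O=C(NCc1ccc(S(=O)(=O)N2CCCCC2)cc1)c1cc2ccncc2[nH]1` gives 50%. Compound 3 `O=C(NCc1ccc(S(=O)(=O)c2ccccc2)cc1)c1nc2cnccc2[nH]1` gives 73%. Compound 3 stands second highest of the three. Its nearest neighbour is compound 1, whose number is higher, but the gap lies within the usual scatter of this assay, so no order between compound 1 and compound 3 can be read from these two values. Its furthest neighbour is compound 2, whose number is lower by a gap that lies beyond the scatter. Within the data shown here, no pair of the three measured compounds differs in one place only, so no single step between them can be isolated.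

Compound 4 `O=C(NCc1ccc(S(=O)(=O)c2ccccc2)cc1)c1ccc2nccn2c1` has not yet been measured. It differs from compound 3 in one place: a group of 9 heavy atoms (7 carbon, 2 nitrogen; one five-membered aromatic ring with 2 hetero atoms, one six-membered aromatic ring with 1 hetero atom) in place of a group of 9 heavy atoms (6 carbon, 3 nitrogen; one five-membered aromatic ring with 2 hetero atoms, one six-membered aromatic ring with 1 hetero atom), on a carbonyl carbon

Among the measured compounds shown here, nothing among the measured compounds mirrors this exchange, so the expectation rests on the spread of the three numbers alone. The step from compound 3 to compound 4 is expected to be small, a number 3 percentage points lower from compound 3 to compound 4 (within the scatter), most likely within the scatter, with no direction favoured. Compound 4 is therefore estimated at 70%, with a range from 50% to 85%.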

Compound 4, percent of the compound remaining: 77%
Compound 4: middle estimate off by 7 percentage points, on the low side; low and high end bracket the measured number.
By their numbers in this assay, from the lowest: compound 2; then compounds 3, 4 and 1 (each within the scatter of the next).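

In this assay, the series now has its first step that changes one place only, and it reads a number 4 percentage points higher from compound 3 to compound 4 (within the scatter). On this carbonyl carbon, the group of 7 carbon and 2 nitrogen atoms can therefore stand in place of the group of 6 carbon and 3 nitrogen atoms with no change that can be told from the usual scatter, so this pair gives no sign that the exchange matters to the read-out. The count falls from 1 hydrogen-bond donor to 0 hydrogen-bond donors in this exchange, and in this one pair that loss comes with no step beyond the scatter. No measurement at hand bears on why the step has this size.

Open, going by these compounds, is whether a group of a different kind on this carbonyl carbon, such as a plain phenyl or a ring carrying a carboxylic acid, would give a step beyond the scatter. Also open, on these data alone, is whether the same exchange would read alike in a compound carrying the piperidine of compound 2, which differs from the other compounds in more than one place, so that its number cannot be assigned to any single part.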